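Ring Nitrogen Substituent: Ethyl Replaced by Isopropylcarbonyl

A few compounds are considered here, and "the series" means these few. Any claim that something is new, unique, unknown or untested is made for them only; others in the source may bear on it.

Compound 1 `COc1cc(/C=C2\CNC/C(=C\c3cc(OC)c(OC)c(OC)c3)C2=O)cc(OC)c1OC` — 1500 nM
Compound 2 `CCN1C/C(=C\c2cc(OC)c(OC)c(OC)c2)C(=O)/C(=C/c2cc(OC)c(OC)c(OC)c2)C1` — 4900 nM

In a functional assay on NCI-H460 cells (Homo sapiens) for cytotoxicity, read by MTT assay, with a stated time of 72 h (a lower number here means a stronger inhibitor, a higher number a weaker inhibitor), compound 2 stands highest of the two measured numbers, with 4900 nM. Compound 3 `COc1cc(/C=C2\CN(C(=O)C(C)C)C/C(=C\c3cc(OC)c(OC)c(OC)c3)C2=O)cc(OC)c1OC` differs from compound 2 by isopropylcarbonyl in place of ethyl on an amine nitrogen in a ring. For the measured compounds named here, the only measured step at this position is a 3.3-fold higher number from compound 1 to compound 2 (0.51 log units; beyond the scatter), a weakening. For compound 3 the expected step is small, in the same weakening direction or none beyond the scatter, a 1.3-fold higher number from compound 2 to compound 3 (0.12 log units; within the scatter). Compound 3 is therefore estimated at 6500 nM, with a range from 2200 nM to 19000 nM.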

Compound 3, half-maximal inhibitory concentration: 2000 nM
Estimate against measurement, compound 3: 3.3-fold (0.51 log units) above; measured number below the stated range.
By their numbers in this assay, from the lowest: compounds 1 and 3 (each within the scatter of the next); then compound 2.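

In this assay, putting isopropylcarbonyl in place of ethyl on the amine nitrogen gives a 2.5-fold lower number from compound 2 to compound 3 (0.39 log units; beyond the scatter), so a substituent on this nitrogen does not always bring the weakening that ethyl alone suggested. Set against the hydrogen on that nitrogen, isopropylcarbonyl gives a 1.3-fold higher number from compound 1 to compound 3 (0.12 log units; within the scatter), which leaves the two level within the scatter. No evidence at hand explains the gap between ethyl and isopropylcarbonyl.

The compounds shown leave open whether the carbonyl or the branched chain goes with the lower number. An acetyl or an isobutyl group on the nitrogen would separate the two.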